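Ketone to alcohol at the aromatic carbon in compound 1

The compounds below may be only part of what the source reports. "The series", "measured", "known", "first", "only" and "open" are said of these compounds alone.

Measured compounds:
compound 1, `CCCCCC(=O)c1ccc(CN(CCCCCCC(=O)O)S(C)(=O)=O)cc1`, 636 nM
compound 2, `Cn1ccnc1CS(=O)(=O)N(Cc1ccc(C(C)(C)C)cc1)Cc1cccc(OCC(=O)O)c1`, 326 nM

In an assay on HEK293 cells for inhibition of prostaglandin E2 receptor EP2 subtype (Rattus norvegicus) (a lower number here means a stronger inhibitor, a higher number a weaker inhibitor), compound 1 gives 636 nM, the higher of the two numbers recorded so far. In this assay compound 2 gives 326 nM; the gap between compound 1 and compound 2 lies within the scatter of repeated measurements, so neither can be ranked against the other. The two compounds share no single point of difference, and nothing beyond their two values can be read from them.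

Compound 3, `CCCCCC(O)c1ccc(CN(CCCCCCC(=O)O)S(C)(=O)=O)cc1`, is not yet measured. It differs from compound 1 in one place: 1-hydroxyhexyl in place of pentylcarbonyl on an aromatic carbon. Going by the values given here, no pair of measured compounds shows what such a change does in this assay, so the step has to be judged from the change alone. With the carbonyl on the chain replaced by a hydroxyl-bearing carbon and the rest of the molecule unchanged, only a small shift is expected, if any, and no direction can be called with confidence. The expected step from compound 1 to compound 3 is a 1.3-fold higher number from compound 1 to compound 3 (0.13 log units; within the scatter), which is within the scatter. Compound 3 is therefore estimated at 850 nM in this assay, with a range from 300 nM to 2500 nM.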

Compound 3, half-maximal inhibitory concentration: 93 nM
The estimate for compound 3 lay 9.1-fold (0.96 log units) above the measured number; measured number outside the range, below it.
By their numbers in this assay, from the lowest: compound 3; then compounds 2 and 1 (each within the scatter of the next).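

In this assay, 1-hydroxyhexyl in place of pentylcarbonyl on the aromatic carbon para to a large group gives a 6.8-fold lower number from compound 1 to compound 3 (0.83 log units; beyond the scatter), so the group at this position matters in this series, even though both groups count the same heavy atoms. Going by these compounds alone, the swap removes the double bond outside the aromatic ring and adds a hydrogen-bond donor, and this pair gives the series its first readable step; compound 2 differs from compound 3 in more than one place, so no step to it can be read. Nothing available ties the lower number to either of those two differences, or to anything else about the change.

The compounds shown leave open whether the hydroxyl hydrogen is what counts, which a methyl ether or an amine on the same carbon would test, and whether the pentyl part of the chain can be shortened or lengthened with the hydroxyl kept in place. Also open, on these data alone, is whether the two mirror-image forms at the hydroxyl-bearing carbon of compound 3 behave alike in this assay.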